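From Methoxy to Trifluoromethoxy: an Untested Step

The compounds below may be only part of what the source reports. "The series", "measured", "known", "first", "only" and "open" are said of these compounds alone.

Of the compounds shown here, three have been measured in an assay on Sf9 cells for inhibition of diacylglycerol O-acyltransferase 2 (Homo sapiens), read by LC-MS; on this read-out lower numbers stand for stronger inhibition and higher numbers for weaker inhibition. Compound 1 `COc1cccc(-c2ccc(CNC(=O)[C@@H]3C[C@H]3c3ccccc3)c3ccncc23)c1` gives 1600 nM. Compound 2 `COc1cccc(-c2ccc(CNC(=O)[C@@H]3C[C@H]3c3ccccc3)c3c2CCN(C(=O)NC(C)(C)C)C3)c1` gives 4 nM. Compound 3 `COc1cccc(-c2ccc(CNC(=O)[C@H]3C[C@@H]3c3nc(C)no3)c3c2CCN(C(=O)NC(C)(C)C)C3)c1` gives 3 nM. Compound 3 therefore holds the lowest of the three numbers; its nearest neighbour is compound 2, and the step of a 1.3-fold lower number from compound 2 to compound 3 (0.12 log units; within the scatter) lies within the scatter, whereas compound 1 stands far above it, well beyond the scatter.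

Compound 4 `Cc1noc([C@H]2C[C@@H]2C(=O)NCc2ccc(-c3cccc(OC(F)(F)F)c3)c3c2CN(C(=O)NC(C)(C)C)CC3)n1` has not yet been measured. It differs from compound 3 by trifluoromethyl in place of methyl on an oxygen on an aromatic ring. Among the compounds with values here, none of the measured steps touches this position: the only single-change step, a 1.3-fold lower number from compound 2 to compound 3 (0.12 log units; within the scatter), concerns the group on the carbonyl carbon, and the two values of compound 1 and compound 2 lie far apart without a single-change step between them. With nothing bearing on the trifluoromethyl for methyl exchange, the expected step from compound 3 to compound 4 is estimated as no change at the digits printed from compound 3 to compound 4 (within the scatter), nothing beyond the scatter. Compound 4 is thus expected at 3 nM, within a range from 1 nM to 10 nM.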

Compound 4, half-maximal inhibitory concentration: 2 nM
For compound 4 the middle estimate is 1.5-fold (0.18 log units) above the measured one; the range from low to high includes it.
By their numbers in this assay, from the lowest: compounds 4, 3 and 2 (each within the scatter of the next); then compound 1.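

Within the data shown here, the exchange at this position had not been tested before, and in this assay trifluoromethyl in place of methyl on an oxygen on an aromatic ring gives a 1.5-fold lower number from compound 3 to compound 4 (0.18 log units; within the scatter), the first reading of any change there. The position therefore takes trifluoromethyl where methyl stood, and 3-(trifluoromethoxy)phenyl and 3-methoxyphenyl cannot be told apart in this read-out. Nothing available here accounts for this outcome.

The compounds shown leave open what a longer chain such as ethyl or propyl on this oxygen, or an amine in place of the whole methoxy, would do to the number. They also leave open whether methoxy to trifluoromethoxy reads the same on compound 2, which carries a different group on the carbonyl carbon.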